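From Cyclopropyl to Ethyl on a Shared Core

A few compounds are considered here, and "the series" means these few. Any claim that something is new, unique, unknown or untested is made for them only; others in the source may bear on it.

Two measured compounds share one core and differ in a single group on an aromatic carbon. Compound 1 `CCC(CCOC)n1c(COC)nc2c(-c3ccc(C(F)(F)F)cc3Cl)ccnc21` carries a methoxymethyl there, and in an assay for binding affinity to Corticotropin releasing factor receptor (Rattus norvegicus) (on this read-out higher numbers stand for weaker inhibition and lower numbers for stronger inhibition), compound 1 gives 82.7 nM. Compound 2 `CCC(CCOC)n1c(C2CC2)nc2c(-c3ccc(C(F)(F)F)cc3Cl)ccnc21` carries a cyclopropyl, and in this assay compound 2 gives 20.8 nM, the lower of the two numbers; the step was a 4.0-fold lower number from compound 1 to compound 2 (0.60 log units; beyond the scatter). Compound 3 `CCc1nc2c(-c3ccc(C(F)(F)F)cc3Cl)ccnc2n1C(CC)CCOC` has not yet been measured; it differs from compound 2 by ethyl in place of cyclopropyl on an aromatic carbon. Going by the values given here, no measured step swaps one small alkyl group for another, so the only known step, a 4.0-fold lower number from compound 1 to compound 2 (0.60 log units; beyond the scatter), bears on this change only loosely, showing that a small group at this place can shift the number. Only a small step is expected, likely toward a slightly higher number. The expected step is a 1.7-fold higher number from compound 2 to compound 3 (0.23 log units; within the scatter). Compound 3 is estimated at 35 nM in this assay, within a range from 12 nM to 100 nM.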

Compound 3, inhibition constant: 0.7 nM
For compound 3 the middle estimate is 50-fold (1.70 log units) above the measured one; the measured number lies below the stated range.
By their numbers in this assay, from the lowest: compound 3; then compound 2; then compound 1.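

On the shared core, ethyl and cyclopropyl are both small carbon-only groups with no hydrogen-bond donors or acceptors, yet in this assay the swap is far from neutral: it gives a 30-fold lower number from compound 2 to compound 3 (1.47 log units; beyond the scatter) and is a large step. Replacing the methoxy of the methoxymethyl group with methyl, which turns that group into ethyl, gives a 120-fold lower number from compound 1 to compound 3 (2.07 log units; beyond the scatter) and is also large, so the three compounds show that this position responds sharply to small changes in the group it carries. No measurement available here explains why ethyl stands so far apart from the other two groups.

From the compounds shown here alone, it remains open whether a methyl, a propyl or a longer chain at this place would give a number as low as ethyl does. The compounds shown also leave open how an amine here would behave, and whether the order of these groups holds when the 1-(2-methoxyethyl)propyl group is changed.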